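Two Tolerated Aryl Ethers and a Methoxy Analogue

This account rests on a few compounds, and the source may have more. Where it says the series, first, only, none or still open, it means among the compounds named here.

Measured compounds:
Compound 1 `CCCCOc1ccc(-c2nc3ncccn3c2NCc2c[nH]cn2)cc1`, in a toxicity assay on A549 cells (Homo sapiens) for cytotoxicity, read by luminescence and CellTiter-Glo, with a stated time of 48 h (a higher number here means that more compound is tolerated, a lower number that less compound is tolerated), compound 1 gives > 100000 nM, a limit of the assay.
Compound 2 `O=C(O)CCCOc1ccc(-c2nc3ncccn3c2NC2CCCCC2)cc1`, in this assay compound 2 gives > 100000 nM, a limit of the assay.

Compound 2 stands at the limit of this assay, and it is not alone there: the limit of > 100000 nM in this assay, at which 2 of the 2 values shown sit. No number, only a limit, is known for either measured compound, so nothing about a difference between compound 1 and compound 2 can be read from these two results.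

Compound 3 `COCCOc1ccc(-c2nc3ncccn3c2NC2CCCCC2)cc1` has not yet been measured in this assay. It differs from compound 2 in one place: methoxy in place of carboxymethyl on a saturated chain carbon, two bonds along the chain from an oxygen on an aromatic ring. The change is methoxy in place of carboxymethyl on a saturated chain carbon, two bonds along the chain from an oxygen on an aromatic ring. Among the compounds with values here, since compound 2 sits at the limit, no measured step gives the size or direction that such a change brings in this assay. Compound 3 is therefore expected to show a step of a number no higher from compound 2 to compound 3 (the limit leaves the size open) from compound 2, none beyond the scatter. The estimate for compound 3 in this assay is 100000 nM, between 30000 nM and 300000 nM, with a fair chance that only a limit is again reported.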

Compound 3, half-maximal cytotoxic concentration: > 100000 nM
Compound 3: a limit, no number (the forecaster's own chance of this, stated with the estimate: 70%); the middle value sits exactly at the limit.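

In this assay compound 3 gives > 100000 nM, a limit of the assay and not a number. Within the data shown here, compound 2 also stands at a limit, so no step from compound 2 to compound 3 can be read. The compounds shown leave open at what concentration any of them becomes cytotoxic, and whether methoxy in place of carboxymethyl changes that concentration: the limit of > 100000 nM in this assay, at which 3 of the 3 values shown sit.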